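This account rests on a few compounds, and the source may have more. Where it says the series, first, only, none or still open, it means among the compounds named here.

Of the compounds shown here, three sharing one core have been read in a functional assay on SMMC-7721 cells (Homo sapiens) for cytotoxicity, read by MTT assay, with a stated time of 72 h; on this read-out lower numbers stand for stronger inhibition and higher numbers for weaker inhibition: compound 1 `O=C1C(=Cc2ccc(O)cc2)C(=O)N(c2ccc(Cl)cc2)N1c1ccc(Cl)cc1` gives 20600 nM, compound 2 `COc1cccc(C=C2C(=O)N(c3ccc(Cl)cc3)N(c3ccc(Cl)cc3)C2=O)c1O` gives 64900 nM, and compound 3 `COc1cccc(C=C2C(=O)N(c3ccc(Cl)cc3)N(c3ccc(Cl)cc3)C2=O)c1` gives 30200 nM. Compound 3 stands close to compound 1, with a 1.5-fold higher number from compound 1 to compound 3 (0.17 log units; within the scatter), and apart from compound 2, with a 2.1-fold lower number from compound 2 to compound 3 (0.33 log units; beyond the scatter).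

The next compound, compound 4 `O=C1C(=C/C=C/c2ccccc2)C(=O)N(c2ccc(Cl)cc2)N1c1ccc(Cl)cc1`, keeps the shared core and differs from compound 3 in one group: 2-phenylethenyl in place of 3-methoxyphenyl on a double-bonded chain carbon bound to a double-bonded ring carbon. Here 2-phenylethenyl stands in place of 3-methoxyphenyl on a double-bonded chain carbon bound to a double-bonded ring carbon.

For the measured compounds named here, no measured step tests this exchange directly, and none of the measured compounds carries 2-phenylethenyl. The closest evidence comes from the other exchanges of the group at this same place. The largest of them, a 3.2-fold higher number from compound 1 to compound 2 (0.50 log units; beyond the scatter), is only modest, and the other two steps quoted above are no larger. As far as these compounds go, on that evidence, no step beyond the scatter is expected in this assay, and the direction remains open. The expected change is a 1.2-fold lower number from compound 3 to compound 4 (0.08 log units; within the scatter). For compound 4 the estimated value is 25000 nM, with an expected range of 8000 nM to 65000 nM.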

Compound 4, half-maximal inhibitory concentration: 10100 nM
Beside the measured number, compound 4's estimate is 2.5-fold (0.39 log units) above it; low and high end bracket the measured number.
By their numbers in this assay, from the lowest: compound 4; then compounds 1 and 3 (each within the scatter of the next); then compound 2.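

For the compounds shown here, at this place, on a double-bonded chain carbon bound to a double-bonded ring carbon, the earlier compounds had only exchanged one substituted phenyl group for another, and 2-phenylethenyl now gives the lowest number of the series in this assay, with a 3.0-fold lower number from compound 3 to compound 4 (0.48 log units; beyond the scatter) and a 2.0-fold lower number from compound 1 to compound 4 (0.31 log units; beyond the scatter) and a 6.4-fold lower number from compound 2 to compound 4 (0.81 log units; beyond the scatter) as the three comparisons. The position therefore accepts a group other than a directly attached phenyl ring, and in this series neither a hydroxy nor a methoxy group on the ring is needed for the lowest number, as the entering group carries a double bond outside aromatic rings and no oxygen. Nothing available here accounts for this difference in the numbers.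

The compounds shown leave open whether the lower number would survive in 2-phenylethyl, where the chain double bond is gone, or in a longer chain such as 4-phenylbuta-1,3-dienyl. They also leave open how a hydroxy, methoxy or dimethylamino group on the ring of 2-phenylethenyl would shift the number.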